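Swapping 3,4-dihydroxyphenyl for 4-aminophenyl in compound 4

A few compounds are considered here, and "the series" means these few. Any claim that something is new, unique, unknown or untested is made for them only; others in the source may bear on it.

Of the compounds shown here, three have been measured in a functional assay on A549 cells (Homo sapiens) for inhibition, read by MTT assay, with a stated time of 72 h; on this read-out lower numbers stand for stronger inhibition and higher numbers for weaker inhibition. Compound 1 (`COc1cc(O)c(CC=C(C)C)c(O)c1C(=O)/C=C/c1cccc([N+](=O)[O-])c1`) gives 15000 nM, and compound 2 (`COc1cc(OC)c(OC)cc1/C=C/C(=O)c1c(O)cc(O)cc1OC`) gives 34200 nM. Compound 3 (`COc1cc(OC)c(C(=O)/C=C/c2ccc(O)c(O)c2)c(OC)c1`) gives 8200 nM, within the scatter of compound 1 and a lower number than compound 2, beyond the scatter. Compound 4 (`COc1cc(OC)c(C(=O)/C=C/c2ccc(N)cc2)c(OC)c1`) has 4-aminophenyl in place of 3,4-dihydroxyphenyl on a double-bonded chain carbon bound to a double-bonded chain carbon. Among the compounds with values here, no measured pair isolates this change, so no firm direction can be drawn from the data. The expected step is a 1.2-fold higher number from compound 3 to compound 4 (0.09 log units; within the scatter), which would be none beyond the scatter in this assay. Compound 4 is estimated at 10000 nM, with an expected range of 3000 nM to 33000 nM.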

Compound 4, half-maximal inhibitory concentration: > 50000 nM
Compound 4 ended at the assay's limit; the forecaster's own chance of this, stated with the estimate: 10%; at least 5.0-fold (0.69 log units) between middle value and limit.
By their numbers in this assay, from the lowest: compounds 3 and 1 (each within the scatter of the next); then compound 2. At a limit, above all of these: compound 4.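

In this assay the group on a double-bonded chain carbon bound to a double-bonded chain carbon now has a direct comparison: 4-aminophenyl in place of 3,4-dihydroxyphenyl gives an at least 6.0-fold higher number from compound 3 to compound 4 (0.78 log units; beyond the scatter) and shows that the read-out depends on the group at this position. Compound 4 gives > 50000 nM as a limit of the assay, so the step sets only a bound on the change: the limit of > 50000 nM in this assay, at which 1 of the 4 values shown sits. The compounds shown leave open whether the two hydroxyl groups or the amine accounts for the difference. A phenyl ring with a single hydroxyl, or an amide in place of the amine, would help separate the two.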